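The compounds below may be only part of what the source reports. "The series", "measured", "known", "first", "only" and "open" are said of these compounds alone.

Two compounds have been measured in an assay on microsomes from brain for inhibition of Fatty-acid amide hydrolase 1 (Rattus norvegicus), read by fluorescence and HPLC, with a stated time of 60 min; a higher number here means a weaker inhibitor, a lower number a stronger inhibitor:

compound 1 `CCCCCCCCc1ccc(OCC(=O)Cn2nnc(Cc3ccccc3)n2)cc1`: 66 nM
compound 2 `CCCCCCCCc1ccc(OCC(=O)Cn2nnnc2-c2ccc(Cl)cc2)cc1`: 130 nM

Compound 2 gives the higher of the two numbers, yet its value and that of compound 1 lie within the scatter of each other, so the two cannot be told apart on these data. Compound 3 `CCCCCCCCc1ccc(OCC(=O)Cn2nnnc2Cc2ccccc2)cc1` is the next member of the series. Relative to compound 2 it changes in one place: benzyl in place of 4-chlorophenyl on an aromatic carbon. Going by the values given here, compound 1 also carries a benzyl on the shared core, and in this assay compound 1 gives 66 nM; that is the only guide available. Among the compounds with values here, no step between two measured compounds covers this change. The step of a 1.7-fold lower number from compound 2 to compound 3 (0.24 log units; within the scatter) is therefore expected to be small, towards a somewhat lower number but hardly beyond the scatter. Compound 3 is estimated at 75 nM, with a likely range from 25 nM to 220 nM.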

Compound 3, half-maximal inhibitory concentration: 320 nM
Compound 3: middle estimate off by 4.3-fold (0.63 log units), on the low side; the measured number lies above the stated range.
By their numbers in this assay, from the lowest: compounds 1 and 2 (each within the scatter of the next); then compound 3.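

In this assay, the aromatic carbon between two ring nitrogen atoms proves sensitive to the group it carries: benzyl in place of 4-chlorophenyl gives a 2.5-fold higher number from compound 2 to compound 3 (0.39 log units; beyond the scatter), a modest step. The two groups have the same count of heavy atoms and each holds one six-membered aromatic ring of carbon only, yet the exchange still moves the number beyond the scatter. The data at hand offer no explanation for this step.

Still open, as far as these compounds go, is whether the step goes with the chlorine or with the carbon that benzyl places before its ring. A plain phenyl or a 4-chlorobenzyl on this same carbon would separate the two, while a 4-methoxyphenyl would show whether another group in the chlorine's place gives a similar number.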